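Amine swap on the chain carbon: compound 1 to compound 3

The source may hold more compounds than are shown below. What is called first, only, known or untested is meant among the compounds shown, and "the series" means these compounds.

Measured so far:
compound 1, `Cc1cccc(Nc2nc(-c3ccncc3)c(CN(C)C)s2)c1`, 16200 nM
compound 2, `FC(F)(F)c1ccc(Nc2nc(-c3ccncc3)cs2)cc1`, 40700 nM

In a functional assay on RCC4 cells (Homo sapiens) for inhibition, read by XTT assay, with a stated time of 4 days (on this read-out lower numbers stand for stronger inhibition and higher numbers for weaker inhibition), compound 1 gives 16200 nM, the lowest of the two numbers. Compound 2 gives 40700 nM, a gap beyond the scatter, though the two differ in more than one place.

Compound 3, `Cc1cccc(Nc2nc(-c3ccncc3)c(CN3CCCCC3)s2)c1`, differs from compound 1 by piperidin-1-yl in place of dimethylamino on a saturated chain carbon bound to an aromatic carbon. Within the data shown here, no measured pair shows this change, so its size rests on nothing here. The step of a 1.2-fold lower number from compound 1 to compound 3 (0.10 log units; within the scatter) is expected to stay within the scatter, with no clear direction. Compound 3 is estimated at 13000 nM, range 4000 nM to 40000 nM.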

Compound 3, half-maximal inhibitory concentration: 13200 nM
Beside the measured number, compound 3's estimate is 1.0-fold (0.01 log units) below it; low and high end bracket the measured number.
By their numbers in this assay, from the lowest: compounds 3 and 1 (each within the scatter of the next); then compound 2.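

Piperidin-1-yl in place of dimethylamino on a saturated chain carbon bound to an aromatic carbon gives a 1.2-fold lower number from compound 1 to compound 3 (0.09 log units; within the scatter) in this assay and the two compounds cannot be told apart on this read-out. Among these compounds, this is the first step read at this position, and it shows that both a ring amine and an open-chain amine can stand here with values inside the scatter of each other. No available data bear on the reason for this result. Still open, from the compounds shown here alone, is how a morpholin-4-yl group, a primary amine or a carboxylic acid would read on this chain carbon. Also open, going by these compounds, is whether a longer chain carrying the same piperidin-1-yl group would stay within the scatter of compound 3.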